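A few compounds are considered here, and "the series" means these few. Any claim that something is new, unique, unknown or untested is made for them only; others in the source may bear on it.

Measured so far:
- compound 1 `CCCCC(=O)N(Cc1ccc(OC)c(O)c1)c1cc(OC)c(OC)c(OC)c1`: 66 nM
- compound 2 `C#CC(=O)N(Cc1ccc(OC)c(O)c1)c1cc(OC)c(OC)c(OC)c1`: 170 nM

In a functional assay on MGC-803 cells (Homo sapiens) for inhibition, read by MTT assay, with a stated time of 48 h (a higher number here means a weaker inhibitor, a lower number a stronger inhibitor), compound 2 gives 170 nM, the higher of the two numbers and so the weaker of the pair. Among the compounds with values here, its only neighbour is compound 1, and the gap between them lies beyond the usual scatter.

The next structure is compound 3 `C/C=C/C=C/C(=O)N(Cc1ccc(OC)c(O)c1)c1cc(OC)c(OC)c(OC)c1`, which keeps the shared core of compound 2. The difference is penta-1,3-dien-1-yl in place of ethynyl on a carbonyl carbon. In words, this is penta-1,3-dien-1-yl in place of ethynyl on a carbonyl carbon.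

Within the data shown here, one measured step bears on this position: a 2.6-fold higher number from compound 1 to compound 2 (0.41 log units; beyond the scatter). It is modest, and it replaces butyl with ethynyl at the same carbonyl carbon. Among the measured compounds shown here, no compound with a penta-1,3-dien-1-yl group has been measured, so the comparison is indirect and rests on a single pair. Ethynyl is the group with the higher number in that pair, so moving away from it is expected to lower the number by a similarly modest amount in this assay. The expected change is a 1.8-fold lower number from compound 2 to compound 3 (0.25 log units; within the scatter), and a result within the scatter would not be surprising.

For compound 3 the estimated value is 95 nM, with an expected range of 30 nM to 300 nM.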

Compound 3, half-maximal inhibitory concentration: 140 nM
Beside the measured number, compound 3's estimate is 1.5-fold (0.17 log units) below it; the measured number falls inside the stated range.
By their numbers in this assay, from the lowest: compound 1; then compounds 3 and 2 (each within the scatter of the next).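

In this assay, penta-1,3-dien-1-yl in place of ethynyl on the carbonyl carbon gives a 1.2-fold lower number from compound 2 to compound 3 (0.08 log units; within the scatter) even though the group entering has 5 heavy atoms and the one leaving has 2, so in this pair the added carbon does not separate the two compounds. Measured against butyl, the same group gives a 2.1-fold higher number from compound 1 to compound 3 (0.33 log units; beyond the scatter) and ethynyl gives a 2.6-fold higher number from compound 1 to compound 2 (0.41 log units; beyond the scatter) so compound 1 remains the strongest of the three, and both chains carrying multiple bonds sit on the weaker side of butyl, with no listed compound going against this. No available measurement explains either the flat step or the gap to butyl.

Butyl and penta-1,3-dien-1-yl differ in both the chain and its multiple bonds, so these compounds leave open which of the two matters; a pentyl chain or a propyl chain on the same carbonyl carbon would begin to separate them. Also open, as far as these compounds go, is how this position responds to groups of a different kind, such as a cyclohexyl ring, a phenyl ring or an amine.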